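The source may hold more compounds than are shown below. What is called first, only, known or untested is meant among the compounds shown, and "the series" means these compounds.

Measured compounds:
Compound 1, `CC(C)C(=O)Nc1cc(Oc2ccc(Nc3nccc4[nH]cc(-c5ccc(F)cc5)c(=O)c34)cc2F)ccn1`, gives 95.4% in a functional assay on MKN-45 cells (Homo sapiens) for antiproliferative activity, read by MTT assay, with a stated time of 72 h, tested at 10 uM; a higher number here means more inhibition at the concentration tested (going by the name of the read-out), a lower number less inhibition.
Compound 2, `CCCC(=O)Nc1cc(Oc2ccc(Nc3nccc4[nH]cc(-c5ccc(F)cc5)c(=O)c34)cc2F)ccn1`, gives 64.6% in this assay.

Going by the values given here, compound 2 stands lowest of the two numbers; its nearest neighbour is compound 1, and the only measured step runs a number 30.8 percentage points lower from compound 1 to compound 2 (beyond the scatter), so the move from a branched to a straight three-carbon chain on the carbonyl carbon cost a large share of the inhibition.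

Compound 3, `CC(C)(O)C(=O)Nc1cc(Oc2ccc(Nc3nccc4[nH]cc(-c5ccc(F)cc5)c(=O)c34)cc2F)ccn1`, has not yet been tested in this assay. It differs from compound 2 in that (1-hydroxy-1-methylethyl in place of propyl on a carbonyl carbon). The entering group is again branched at the carbon attached to the carbonyl, as isopropyl is in compound 1, and it carries a hydroxyl in addition. Among the compounds with values here, the one step that bears on this change is a number 30.8 percentage points lower from compound 1 to compound 2 (beyond the scatter), which shows that branching at this position goes with the higher number. Whether the added hydroxyl shifts the number further cannot be read from these two compounds alone.

Compound 3 is therefore expected to rise relative to compound 2, with a step of a number 15.4 percentage points higher from compound 2 to compound 3 (beyond the scatter), and the estimate for compound 3 is 80% within a range of 55% to 98%.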

Compound 3, a percentage reported as inhibition, at one concentration (the size of the read-out at that concentration, not a potency): 57.8%
For compound 3 the middle estimate is 22.2 percentage points above the measured one; the range from low to high includes it.
By their numbers in this assay, from the lowest: compounds 3 and 2 (each within the scatter of the next); then compound 1.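

In this assay, placing a hydroxy on the saturated chain carbon bound to the carbonyl carbon is a single change that gives a number 37.6 percentage points lower from compound 1 to compound 3 (beyond the scatter) and so separates 1-hydroxy-1-methylethyl sharply from isopropyl, even though both groups are branched at that carbon. Replacing propyl with 1-hydroxy-1-methylethyl gives a number 6.8 percentage points lower from compound 2 to compound 3 (within the scatter) and leaves compound 3 level with compound 2, so branching at this carbon does not by itself go with the higher number: compound 1 stands high, while compound 3 goes against any such pattern. Nothing available explains why the hydroxy has this effect at this position.

On these data alone, what remains open is whether the loss belongs to the hydroxyl itself or would also follow from a methoxy, a fluorine or an amine on the same carbon, and whether a tert-butyl or a cyclopropyl would keep the number seen with isopropyl. As far as these compounds go, these readings also come from a single concentration, so how the three compounds compare in potency remains open.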